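Three Carbonate and Ester Variants, All Beyond the Cytotoxicity Limit

The compounds below may be only part of what the source reports. "The series", "measured", "known", "first", "only" and "open" are said of these compounds alone.

Compound 1, `CCCCOC(=O)OCC1OC(n2cc(C)c(=O)[nH]c2=O)CC1N=[N+]=[N-]`, in a functional assay on MT4 cells (Homo sapiens) for cytotoxicity (a lower number here means that less compound is tolerated, a higher number that more compound is tolerated), gives a limit of > 50000 nM.
Compound 2, `Cc1cn(C2CC(N=[N+]=[N-])C(COC(=O)OCCO)O2)c(=O)[nH]c1=O`, in this assay gives a limit of > 50000 nM.
Compound 3, `Cc1cn(C2CC(N=[N+]=[N-])C(COC(=O)CCCN)O2)c(=O)[nH]c1=O`, in this assay gives a limit of > 50000 nM.

None of the three measured compounds yields a number in this assay; each sits at the limit of > 50000 nM in this assay, at which 3 of the 3 values shown sit. Compound 3 therefore stands at the limit, where the two other values shown also stand, and no ordering among them can be read.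

The change from compound 3 to the unmeasured compound 4, `Cc1cn(C2CC(N=[N+]=[N-])C(COC(=O)OCCCO)O2)c(=O)[nH]c1=O`, is 3-hydroxypropoxy in place of 3-aminopropyl on a carbonyl carbon. The steps measured at this carbonyl carbon are a step that the two limits leave unreadable from compound 1 to compound 3 and a step that the two limits leave unreadable from compound 2 to compound 3; both run between two limits and give no readable size. The step that the two limits leave unreadable from compound 1 to compound 2 is likewise unreadable. For the measured compounds named here, nothing among the measured compounds shows a substituent at this carbonyl carbon that brings the readout within the measurable range, so no step beyond the scatter is expected from this change.

Compound 4 is expected to give 50000 nM, between 30000 nM and 120000 nM, most likely again as a limit. The expected step is a number no higher from compound 3 to compound 4 (the limit leaves the size open), none beyond the scatter.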

Compound 4, half-maximal cytotoxic concentration: > 50000 nM
Compound 4 gave a limit, no number (the forecaster's own chance of this, stated with the estimate: 90%); the middle value sits exactly at the limit.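

In this assay compound 4 gives > 50000 nM, which is a limit and not a number. The steps joining compound 4 to compound 1, compound 2 and compound 3 cannot be read, because all of these compounds stand at the same limit: the limit of > 50000 nM in this assay, at which 4 of the 4 values shown sit.

The compounds shown leave open how these four rank and whether any group on this carbonyl carbon gives a number in this assay.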